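Alkynyl sulfonamides: fluorine added to the pendant phenyl

A few compounds are considered here, and "the series" means these few. Any claim that something is new, unique, unknown or untested is made for them only; others in the source may bear on it.

Measured compounds in a functional assay on HCT-116 cells (Homo sapiens) for antiproliferative activity, read by MTT assay, with a stated time of 68 h; on this read-out higher numbers stand for weaker inhibition and lower numbers for stronger inhibition:
compound 1 `Cc1n[nH]c2ncc(C#Cc3c(F)ccc(NS(=O)(=O)c4cccnc4)c3F)cc12`, which gives 4630 nM.
compound 2 `O=S(=O)(Nc1ccc(F)c(C#Cc2cnc3[nH]nc(-c4ccccc4)c3c2)c1F)c1cccnc1`, which gives only a limit of the assay, > 10000 nM.

Compound 2 stands at the weak end of the two numbers shown; its value is a limit, not a number, so its true potency is open above that point. Among the compounds with values here, the single measured step, an at least 2.1-fold higher number from compound 1 to compound 2 (0.33 log units; beyond the scatter), runs into that limit, as noted by the limit of > 10000 nM in this assay, at which 1 of the 2 values shown sits.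

Compound 3 `O=S(=O)(Nc1ccc(F)c(C#Cc2cnc3[nH]nc(-c4ccc(F)cc4)c3c2)c1F)c1cccnc1` differs from compound 2 by fluoro in place of hydrogen on an aromatic carbon. Within the data shown here, no measured step touches this position: the only step in hand, an at least 2.1-fold higher number from compound 1 to compound 2 (0.33 log units; beyond the scatter), changes the whole group from methyl to phenyl, which is a different kind of change, and it ends at a limit rather than at a number. There is therefore nothing to anchor a direction for a single fluorine on the phenyl, and no step beyond the scatter is expected, a step that the limit leaves unreadable from compound 2 to compound 3.

Compound 3 is estimated at 12000 nM, with a range of 5000 nM to 30000 nM in this assay, and a clear chance that only a limit is reported again.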

Compound 3, half-maximal inhibitory concentration: > 10000 nM
Compound 3: only a limit was reported; the forecaster's own chance of this, stated with the estimate: 65%; the middle value is on the limit's open side.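

With 4-fluorophenyl as with phenyl, the weak result at this position is no longer tied to a single compound, and the replacement of methyl again carries a measurable cost in this assay: an at least 2.1-fold higher number from compound 1 to compound 3 (0.33 log units; beyond the scatter). The step between compound 2 and compound 3 cannot be read, as both values are limits, so the series gives no size or direction for fluoro in place of hydrogen on the phenyl. What is new is only that adding this fluoro does not bring the value back into the measurable range, and the two aryl compounds now share one ceiling: the limit of > 10000 nM in this assay, at which 2 of the 3 values shown sit.

As far as these compounds go, it remains open whether another group in place of the methyl of compound 1, such as an ethyl, a methoxy or an amine, would give a lower number than compound 1 at 4630 nM. From the compounds shown here alone, how far the true values of the two aryl compounds lie beyond the limit also remains open, and so does whether a fluoro on the phenyl has any effect on potency at all.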